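Swapping chloro for fluoro on a fused-ring inhibitor

A few compounds are considered here, and "the series" means these few. Any claim that something is new, unique, unknown or untested is made for them only; others in the source may bear on it.

Compound 1 `COc1cc(N(CC2CC2)c2ccc(Cl)c3ccccc23)cnc1C(=O)[C@H]1C[C@@H]1C(=O)O` is the starting point. Going by the values given here, in an assay on isolated protein for inhibition of leukotriene C4 synthase (Homo sapiens), read by LC-MS, with stated times of 45 min and 20 min (a lower number here means a stronger inhibitor, a higher number a weaker inhibitor), compound 1 gives 9.41 nM, the lowest of the two numbers measured so far. The nearest comparison is compound 2 `COc1cc(N(CC2CC2)c2ccc(Cl)c(Cl)c2)cnc1C(=O)[C@H]1C[C@@H]1C(=O)O`, which in this assay gives 27.7 nM, a gap beyond the usual scatter. For compound 3 `COc1cc(N(CC2CC2)c2ccc(Cl)c3ccccc23)cnc1C(=O)CCCC(=O)O` the result in this assay is "not determined" (no result reported), so it adds nothing to the comparison.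

Compound 4 `COc1cc(N(CC2CC2)c2ccc(F)c3ccccc23)cnc1C(=O)[C@H]1C[C@@H]1C(=O)O` differs from compound 1 in one place: fluoro in place of chloro on an aromatic carbon. Among the compounds with values here, no pair of measured compounds shows this exact exchange, so the size of the step cannot be read from a measured pair. Swaps of one halogen for another on a ring usually shift the numbers only modestly, and the expected step from compound 1 to compound 4 is a 1.7-fold higher number from compound 1 to compound 4 (0.23 log units; within the scatter), a small loss at most, possibly none beyond the scatter. Compound 4 is therefore expected to give about 16 nM, within a range from 6 nM to 45 nM.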

Compound 4, half-maximal inhibitory concentration: 26.5 nM
Compound 4: the middle estimate sits 1.7-fold (0.22 log units) below what was measured; the range from low to high includes it.
By their numbers in this assay, from the lowest: compound 1; then compounds 4 and 2 (each within the scatter of the next).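

In this assay this position proves sensitive to which halogen it carries: fluoro in place of chloro gives a 2.8-fold higher number from compound 1 to compound 4 (0.45 log units; beyond the scatter) and so costs a modest but real amount of inhibition. Chloro and fluoro each add one heavy atom and count no hydrogen-bond donors or acceptors, so those counts alone do not separate compound 1 from compound 4, yet the measured numbers do. Nothing measured here accounts for the loss.

The compounds shown leave open how bromo, methyl or a nitrile would read at this same place on the ring, and whether any of them could match chloro. They also leave open whether the exchange of chloro for fluoro would cost as much on a core with a longer chain carrying the carboxylic acid.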